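The compounds below may be only part of what the source reports. "The series", "measured", "known", "first", "only" and "open" are said of these compounds alone.

Compound 1 `COc1cc(/C=C/C(=O)C2=C(/C=C/c3ccc(O)c(OC)c3)NC(=O)NC2c2c(Cl)cccc2Cl)ccc1O` gives 11.2% in a functional assay, with a stated time of 20 min, tested at 2 uM; on this read-out higher numbers stand for a stronger effect at the one concentration tested and lower numbers for a weaker effect.
Compound 2 `COc1cc(/C=C/C(=O)C2=C(/C=C/c3ccc(O)c(OC)c3)NC(=S)NC2c2ccc(C)cc2)ccc1O` gives 15.5% in this assay.

Going by the values given here, of the two numbers measured so far in this assay, compound 2 stands at the top, yet its only neighbour, compound 1, lies just a few points lower, a gap that falls within the usual scatter of this kind of measurement. Both compounds therefore sit in the same weak region of the read-out, and nothing separates them with confidence.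

Compound 3 `COc1cc(/C=C/C(=O)C2=C(/C=C/c3ccc(O)c(OC)c3)NC(=S)NC2c2c(Cl)cccc2Cl)ccc1O` has not yet been measured. It departs from compound 2 in a single place: 2,6-dichlorophenyl in place of 4-methylphenyl on a saturated ring carbon. Among the compounds with values here, the group that enters is the one already carried by compound 1, whose value in this assay is 11.2%. Within the data shown here, no step between measured compounds that differ in one place is available, so the expectation can rest only on the closeness of the two measured numbers: no change beyond the scatter is expected in this assay.

Compound 3 is thus estimated to give 13%, with a range from 3% to 25%. That estimate means a step of a number 2.5 percentage points lower from compound 2 to compound 3 (within the scatter), expected to stay within the scatter.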

Compound 3, a percentage reported as activity, at one concentration (the size of the read-out at that concentration, not a potency): 17.7%
Compound 3: middle estimate off by 4.7 percentage points, on the low side; the range from low to high includes it.
By their numbers in this assay, from the lowest: compounds 1, 2 and 3 (each within the scatter of the next).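

On the saturated ring carbon of the six-membered ring with 2 nitrogen, putting 2,6-dichlorophenyl in place of 4-methylphenyl gives, in this assay, a number 2.2 percentage points higher from compound 2 to compound 3 (within the scatter). This single exchange therefore leaves the read-out within the usual scatter, even though the two groups differ in their atoms, one carrying 2 chlorine and the other none, and both compounds remain in the same weak region at the one concentration tested. Nothing at hand says why this position tolerates the exchange, or whether the two groups act alike at all beyond this one read-out.

Going by these compounds, both groups at this position are substituted phenyl rings, so it remains open whether a phenyl ring bearing an amine or a carboxylic acid, or a plain alkyl chain such as butyl in place of the ring, would carry the read-out beyond the scatter. All the compounds shown also keep both the 2-(4-hydroxy-3-methoxyphenyl)ethenyl group and its counterpart on the carbonyl side, so what the shared core contributes to this weak read-out, and what replacing either arm would do, remains unanswered.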